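Amide in Place of Methyl on a Toll-like Receptor 8 Agonist

A few compounds are considered here, and "the series" means these few. Any claim that something is new, unique, unknown or untested is made for them only; others in the source may bear on it.

Measured so far:
- compound 1, `CCCCNc1nc(N)nc2cc(CN(C)C)ccc12`: 0.04 uM
- compound 2, `CCCCNc1nc(N)nc2cccc(C)c12`: 0.3 uM

Of the compounds shown here, two have been measured in an ADME assay on HEK293 cells for agonist activity at Toll-like receptor 8 (Homo sapiens), read by a luciferase reporter, with a stated time of 6 h; on this read-out higher numbers stand for an effect only at larger amounts of compound and lower numbers for an effect already at smaller amounts. Compound 1 gives 0.04 uM. For the measured compounds named here, compound 2 gives 0.3 uM and so stands at the highest of the two numbers; the only neighbour is compound 1, whose number is lower by a gap beyond the usual scatter. The two differ in more than one place, so nothing can be said about which change accounts for that gap.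

Compound 3, `CCCCNc1nc(N)nc2cccc(C(=O)NC)c12`, is not yet measured. It differs from compound 2 in one place: methylcarbamoyl in place of methyl on an aromatic carbon.

Going by the values given here, no measured pair shows the effect of such a change here, so the expected step rests on compound 2 alone. Among the compounds with values here, a group with a hydrogen-bond donor and acceptor enters where a methyl left; no measured compound tells in which direction this moves the number. The step of a 1.5-fold lower number from compound 2 to compound 3 (0.18 log units; within the scatter) is therefore estimated as small, perhaps not beyond the scatter, with a slight lean toward a lower number. Compound 3 is estimated at 0.2 uM, within a range from 0.03 uM to 1.2 uM.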

Compound 3, minimum effective concentration: 0.39 uM
The estimate for compound 3 lay 2.0-fold (0.29 log units) below the measured number; the measured number falls inside the stated range.
By their numbers in this assay, from the lowest: compound 1; then compounds 2 and 3 (each within the scatter of the next).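

In this assay, methylcarbamoyl in place of methyl on this aromatic carbon gives a 1.3-fold higher number from compound 2 to compound 3 (0.11 log units; within the scatter) and so leaves the two compounds indistinguishable on this read-out. For the compounds shown here, this is the first change at a single place, and it shows that four heavy atoms, with a hydrogen-bond donor and a hydrogen-bond acceptor among them, can stand where one methyl carbon stood without moving the number beyond the usual scatter. No measurement available here says why the number holds.

A single pair cannot show whether an amine, a carboxylic acid or a longer chain on this carbon would leave the number just as steady, or whether a dimethylcarbamoyl group, which lacks the amide hydrogen, would do the same. It also leaves open whether the same swap would be as quiet elsewhere on the shared core, such as at the place where compound 1 carries its dimethylaminomethyl group.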